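The source may hold more compounds than are shown below. What is called first, only, known or untested is meant among the compounds shown, and "the series" means these compounds.

Of the compounds shown here, three have so far been measured in a functional assay on cells (Macrophage, Mus musculus, strain ddY) for inhibition, read by Griess assay, with a stated time of 20 h; a lower number here means a stronger inhibitor, a higher number a weaker inhibitor. Compound 1 `C=C(C)[C@H]1C=C2[C@](C)(CCC[C@@]2(C)O)CC1` gives 42000 nM, compound 2 `C=C(C)[C@@H]1CC[C@@]2(C)CC[C@@H](O)C(=C)C2C1` gives 21000 nM, and compound 3 `CC(C)[C@@H]1CCC(=O)C2=C1[C@H](O)[C@](C)(O)CC2` gives 28000 nM. Compound 3 stands second highest of the three numbers, yet its gaps to compound 2 and to compound 1 both lie within the usual scatter, so no order can be read among them. Compound 4 `CC(C)[C@H]1CCC(=O)C2=C1[C@H](O)[C@](C)(O)CC2` differs from compound 3 as follows: the two compounds have the same atoms and bonds and differ only in configuration as drawn: 1 of 3 stereo elements differ; a stereocentre at a saturated ring carbon is drawn S in compound 3 and R in compound 4. Among the measured compounds shown here, no step between measured compounds shows what such a change of configuration does here, so the expectation rests only on the closeness of the three values. Compound 4 is expected to give about 28000 nM, lying between 12000 nM and 65000 nM. The estimated step of no change at the digits printed from compound 3 to compound 4 (within the scatter) is expected to stay within the scatter, with no clear direction.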

Compound 4, half-maximal inhibitory concentration: > 100000 nM
Compound 4 was reported as a limit (the forecaster's own chance of this, stated with the estimate: 10%); middle value at least 3.5-fold (0.55 log units) away from the limit.
By their numbers in this assay, from the lowest: compounds 2, 3 and 1 (each within the scatter of the next). At a limit, above all of these: compound 4.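

Changing one stereocentre at a saturated ring carbon from S to R gives an at least 3.5-fold higher number from compound 3 to compound 4 (0.55 log units; beyond the scatter) in this assay. Compound 4 gives > 100000 nM, which is a limit of the assay and not a number. The earlier compounds showed no such step, and this one can be put down to configuration alone, because nothing else changes: the fact that compounds 3 and 4 differ only in the configuration as drawn

The compounds shown leave open whether the other two stereo elements matter as much as this one. They also leave open whether an amine or a carboxylic acid on the shared core would change the number in compound 3.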